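A methoxy for dichloro swap on the shared core

The source may hold more compounds than are shown below. What is called first, only, known or untested is meant among the compounds shown, and "the series" means these compounds.

Of the compounds shown here, three sharing one core have been tested in an ADME assay on THP-1 cells (Homo sapiens) for cytotoxicity, read by MTT assay, tested at 50 ug/mL; a lower number here means less inhibition, a higher number more inhibition at the concentration tested (going by the name of the read-out). Compound 1 `C(=N/Nc1nc(-c2ccccc2)cs1)\c1ccc(-n2ccnc2)cc1` gives 21.8%. Compound 2 `Brc1ccc(-c2csc(N/N=C/c3ccc(-n4ccnc4)cc3)n2)cc1` gives 36.8%, and the step of a number 15 percentage points higher from compound 1 to compound 2 (beyond the scatter) is the only one here that clears the scatter. Compound 3 `Clc1ccc(-c2csc(N/N=C/c3ccc(-n4ccnc4)cc3)n2)c(Cl)c1` gives 28.8%; its number sits in the middle of the three, within the usual scatter of both compound 1 and compound 2, so no order among these two neighbours can be claimed.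

Compound 4 `COc1ccc(-c2csc(N/N=C/c3ccc(-n4ccnc4)cc3)n2)cc1` is not yet measured. It differs from compound 3 in one place: 4-methoxyphenyl in place of 2,4-dichlorophenyl on an aromatic carbon. Among the compounds with values here, the steps that bear on this change are all at the same aromatic carbon of the five-membered ring: a number 8 percentage points lower from compound 2 to compound 3 (within the scatter) and a number 7 percentage points higher from compound 1 to compound 3 (within the scatter) stayed inside the scatter, while a number 15 percentage points higher from compound 1 to compound 2 (beyond the scatter) was modest. Within the data shown here, no halogen-free six-membered group carrying an acceptor has been tried on that carbon, so the expectation rests on the narrow spread of the three numbers so far.

For compound 4 a value near the measured cluster is therefore expected, 26% with a range from 12% to 40%. The expected step of a number 2.8 percentage points lower from compound 3 to compound 4 (within the scatter) is estimated to be small, most likely within the scatter.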

Compound 4, a percentage reported as inhibition, at one concentration (the size of the read-out at that concentration, not a potency): 26.8%
Compound 4: middle estimate off by 0.8 percentage points, on the low side; measured number inside the range.
By their numbers in this assay, from the lowest: compounds 1, 4, 3 and 2 (each within the scatter of the next, the first and the last beyond it).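

Within the data shown here, with 4-methoxyphenyl in place of 2,4-dichlorophenyl on this aromatic carbon next to the ring nitrogen, this assay gives a number 2 percentage points lower from compound 3 to compound 4 (within the scatter) for a swap between two groups of equal heavy-atom count, so the hydrogen-bond acceptor of 4-methoxyphenyl and the loss of both chlorines bring no step that can be told from the scatter. Methoxy in place of bromo gives a number 10 percentage points lower from compound 2 to compound 4 (within the scatter) and methoxy in place of hydrogen gives a number 5 percentage points higher from compound 1 to compound 4 (within the scatter) on the same carbon, so methoxy, unlike bromo with its a number 15 percentage points higher from compound 1 to compound 2 (beyond the scatter), does not separate from the unsubstituted phenyl of compound 1. Nothing at hand accounts for any of these steps.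

On these data alone, whether an amine or a carboxylic acid in place of methoxy, or a longer chain such as butoxy, would carry the number beyond the scatter remains open. As far as these compounds go, all four numbers also come from a single concentration, so how the compounds compare in potency stays unknown.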